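This account rests on a few compounds, and the source may have more. Where it says the series, first, only, none or still open, it means among the compounds named here.

Series in a functional assay on SW480 cells (Homo sapiens) for cytotoxicity, read by MTT assay, with a stated time of 48 h; on this read-out higher numbers stand for weaker inhibition and lower numbers for stronger inhibition:
- compound 1 `CCOC(=O)C1(C(=O)Nc2ccccc2)CC1c1cc(OC)c(OC)c(OC)c1`: 49000 nM; > 100000 nM (2 entries)
- compound 2 `CCOC(=O)[C@]1(C(=O)Nc2ccccc2)C[C@H]1c1cc(OC)c(OC)c(OC)c1`: > 100000 nM (a limit)
- compound 3 `CCOC(=O)[C@]1(C(=O)Nc2ccccc2)C[C@@H]1c1cc(OC)c(OC)c(OC)c1`: 31700 nM

Among the compounds with values here, compound 3 holds the only single number, as the entries for compound 1 do not agree on one value (the several entries of compound 1 in this assay, 49000 nM; > 100000 nM (2 entries)). Compound 2 sits at a limit (the limit of > 100000 nM in this assay, at which 1 of the 3 values shown sits).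

The next structure is compound 4 `CCOC(=O)[C@@]1(C(=O)Nc2ccccc2)C[C@H]1c1cc(OC)c(OC)c(OC)c1`, the mirror image of compound 3: the two compounds have the same atoms and bonds and differ only in configuration as drawn: 2 of 2 stereo elements differ (all stereocentres are inverted: mirror images); a stereocentre at a saturated ring carbon is drawn R in compound 3 and S in compound 4; a stereocentre at a saturated ring carbon is drawn R in compound 3 and S in compound 4.

Within the data shown here, the one clean step that bears on this change is an at least 3.1-fold lower number from compound 2 to compound 3 (0.49 log units; beyond the scatter). It involves configuration alone the fact that compounds 2 and 3 differ only in the configuration as drawn and lies beyond the scatter, so configuration can matter in this assay. Going by these compounds, its true size remains open, since it starts from a limit. Among the measured compounds shown here, compound 1 gives no clean step, as it is drawn without the defined configuration of compound 3 the fact that one of compounds 1 and 3 is drawn with a defined configuration and the other without, at the place where they differ or compound 2 (the fact that one of compounds 1 and 2 is drawn with a defined configuration and the other without, at the place where they differ).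

A modest move towards a higher number, meaning weaker inhibition, is therefore expected, and a report of only a limit is about as likely as a number. The expected size is a 2.2-fold higher number from compound 3 to compound 4 (0.34 log units; beyond the scatter). The estimate for compound 4 is 70000 nM, with an expected range from 25000 nM to 200000 nM.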

Compound 4, half-maximal inhibitory concentration: > 100000 nM
Compound 4: only a limit was reported; the forecaster's own chance of this, stated with the estimate: 55%; at least 1.4-fold (0.15 log units) between middle value and limit.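

In this assay, going by these compounds, inverting both stereocentres of compound 3 gives an at least 3.1-fold higher number from compound 3 to compound 4 (0.49 log units; beyond the scatter), so the full mirror image also loses activity, although the true size of this step remains open because it ends at a limit: the fact that compounds 3 and 4 differ only in the configuration as drawn. Inverting a single stereocentre had already given an at least 3.1-fold lower number from compound 2 to compound 3 (0.49 log units; beyond the scatter), and compound 3 now stands apart from both of the other defined forms shown, as the only one of the three with a single number. Compound 4 joins compound 2 at the limit of this assay, and the step between them cannot be read: the limit of > 100000 nM in this assay, at which 2 of the 4 values shown sit.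

On these data alone, compound 1 adds no clean comparison with compound 4, and the depth of the configuration effect stays unknown, with both readable steps starting or ending at a limit: the fact that one of compounds 1 and 4 is drawn with a defined configuration and the other without, at the place where they differ. The compounds shown also leave open whether the preference for the configuration of compound 3 would hold with a carboxylic acid in place of the ethyl ester, or with an amine on the anilide phenyl group.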